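The source may hold more compounds than are shown below. What is called first, only, known or untested is meant among the compounds shown, and "the series" means these compounds.

Compound 1 `CC(C)(C)CCC1([C@H](O)/C=C/[C@H]2COC(=O)N2CCSc2nc(C(=O)O)cs2)CCC1`: 149 nM in an assay on isolated protein for binding affinity to prostaglandin E2 receptor EP1 subtype (Homo sapiens); a higher number here means a weaker inhibitor, a lower number a stronger inhibitor.
Compound 2 `CC#CCC1([C@H](O)/C=C/[C@H]2COC(=O)N2CCSc2nc(C(=O)O)cs2)CCC1`: 89 nM in this assay.

Within the data shown here, compound 1 has the highest of the two numbers, but its only neighbour lies within the scatter: a 1.7-fold lower number from compound 1 to compound 2 (0.22 log units; within the scatter). Compound 3 `COCCCC1([C@H](O)/C=C/[C@H]2COC(=O)N2CCSc2nc(C(=O)O)cs2)CCC1` differs from compound 1 by methoxymethyl in place of tert-butyl on a saturated chain carbon, two bonds along the chain from a saturated ring carbon. Among the measured compounds shown here, no measured step swaps a hydrocarbon terminus for an oxygen-bearing one, so the single comparison is only a loose guide; with a 1.7-fold lower number from compound 1 to compound 2 (0.22 log units; within the scatter) a change at this end of the chain left the number essentially unchanged, and no step beyond the scatter is expected in this assay. Compound 3 is expected at 200 nM, between 60 nM and 700 nM. This corresponds to an expected 1.3-fold higher number from compound 1 to compound 3 (0.13 log units; within the scatter).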

Compound 3, inhibition constant: > 10000 nM
Compound 3 ended at the assay's limit (the forecaster's own chance of this, stated with the estimate: 3%); at least 50-fold (1.69 log units) between middle value and limit.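

The chain end at this position is far less forgiving than the earlier pair suggested: a 1.7-fold lower number from compound 1 to compound 2 (0.22 log units; within the scatter) stayed within the scatter. Methoxymethyl in place of tert-butyl gives an at least 67-fold higher number from compound 1 to compound 3 (1.82 log units; beyond the scatter), and 2-methoxyethyl in place of prop-1-yn-1-yl gives an at least 110-fold higher number from compound 2 to compound 3 (2.05 log units; beyond the scatter). Compound 3 stands as a limit in this assay, not as a number, so both steps are minimum sizes: the limit of > 10000 nM in this assay, at which 1 of the 3 values shown sits.

Whether the ether oxygen alone accounts for this stays open. A plain pentyl chain, or a terminal hydroxyl or amine, would bear on that question.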